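This account rests on a few compounds, and the source may have more. Where it says the series, first, only, none or still open, it means among the compounds named here.

Measured compounds:
- compound 1 `O=C(NCc1cc(Cl)ccc1-n1cnnn1)[C@@H]1[C@H]2C[C@H]2CN1C(=O)[C@H](O)CC1CC1` gives 1400 nM in a functional assay on a cell-free system (plasma, Homo sapiens), with a stated time of 3 min; a higher number here means a weaker inhibitor, a lower number a stronger inhibitor
- compound 2 `O=C(NCc1cc(Cl)ccc1-n1cnnn1)[C@@H]1C[C@@H]2C[C@@H]2N1C(=O)[C@H](O)CC1CC1` gives 1700 nM in this assay
- compound 3 `CC(C)(C)[C@@H](O)C(=O)N1CC[C@@H]2C[C@@]21C(=O)NCc1cc(Cl)ccc1-n1cnnn1` gives 1500 nM in this assay

Three compounds sharing the same amide-linked aryl tetrazole fragment have been run in this assay, and their numbers sit close together. Compound 1 carries the lowest figure of the three, but its distance to compound 3 and to compound 2 both fall within the usual scatter of repeated measurements, so the three cannot be told apart on these data; none of them stands out as stronger or weaker.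

The next compound, compound 4 `CC(C)(C)C[C@@H](O)C(=O)N1C[C@@H]2C[C@@H]2[C@H]1C(=O)NCc1cc(Cl)ccc1-n1cnnn1`, has not yet been measured. It differs from compound 1 in a single place: tert-butyl in place of cyclopropyl on a saturated chain carbon, two bonds along the chain from a carbonyl carbon and an oxygen on a saturated carbon. The hydroxy acyl group on the core is thus changed from cyclopropylmethyl to neopentyl, while the core of compound 1 and the aryl tetrazole part remain the same.

Going by the values given here, no pair of measured compounds shows this change, so the size of the step is unknown. Given how tightly compound 1, compound 2 and compound 3 cluster in this assay, and that compound 3 already carries a tert-butyl near the same hydroxyl and gives 1500 nM, the expected step of a 1.2-fold lower number from compound 1 to compound 4 (0.07 log units; within the scatter) is small, likely not beyond the scatter in either direction. Compound 4 is accordingly expected to give about 1200 nM, within a range of 500 nM to 3000 nM.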

Compound 4, half-maximal inhibitory concentration: 910 nM
Estimate against measurement, compound 4: 1.3-fold (0.12 log units) above; measured number inside the range.
By their numbers in this assay, from the lowest: compounds 4, 1, 3 and 2 (each within the scatter of the next).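

In this assay, going by these compounds alone, replacing cyclopropyl with tert-butyl on a saturated chain carbon, two bonds along the chain from a carbonyl carbon and an oxygen on a saturated carbon, gives a 1.5-fold lower number from compound 1 to compound 4 (0.19 log units; within the scatter), the first step at this position that can be read directly. It shows that, on the core of compound 1, cyclopropylmethyl can give way to neopentyl, removing the three-membered ring, without the number moving beyond the scatter, so compound 1 and compound 4 cannot be told apart here. No measurement shown accounts for the size of this step, and the result carries no explanation of its own.

The compounds shown leave open whether a different group at this place, such as an amine, a carboxylic acid or a longer chain, would produce a step beyond the scatter. As far as these compounds go, it also remains open whether the change from cyclopropylmethyl to neopentyl would give a step of similar size on the core of compound 2, and whether the hydroxyl on the acyl group matters at all in this assay.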